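Swapping cyano for sulfamoyl at the assay limit

A few compounds are considered here, and "the series" means these few. Any claim that something is new, unique, unknown or untested is made for them only; others in the source may bear on it.

- compound 1 `Cc1ccc(/C=c2\sc3nc(-c4cn(C5CC5)c5cc(N6CCN(C)CC6)c(F)cc5c4=O)nn3c2=O)cc1` - > 10000 nM (a limit)
- compound 2 `CN1CCN(c2cc3c(cc2F)c(=O)c(-c2nc4s/c(=C\c5cccc(C#N)c5)c(=O)n4n2)cn3C2CC2)CC1` - > 10000 nM (a limit)
- compound 3 `CN1CCN(c2cc3c(cc2F)c(=O)c(-c2nc4s/c(=C\c5ccc(C#N)cc5)c(=O)n4n2)cn3C2CC2)CC1` - > 10000 nM (a limit)

In a functional assay on Hep 3B2 cells (Homo sapiens) for cytotoxicity (on this read-out lower numbers stand for stronger inhibition and higher numbers for weaker inhibition), compound 3 has no number, only the limit > 10000 nM as its reading. The series as a whole offers (the limit of > 10000 nM in this assay, at which 3 of the 3 values shown sit), so the three compounds cannot be ranked against one another.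

Compound 4 `CN1CCN(c2cc3c(cc2F)c(=O)c(-c2nc4s/c(=C\c5ccc(S(N)(=O)=O)cc5)c(=O)n4n2)cn3C2CC2)CC1` keeps the rest of compound 3 and changes one group: sulfamoyl in place of cyano on an aromatic carbon, para to a large group (sulfamoyl in place of cyano on an aromatic carbon). For the measured compounds named here, two measured steps bear on this change. Going by the values given here, the first is a step that the two limits leave unreadable from compound 1 to compound 3, with cyano in place of methyl on an aromatic carbon. The second is a step that the two limits leave unreadable from compound 2 to compound 3, with 4-cyanophenyl in place of 3-cyanophenyl. Neither gives a size or a direction that could be carried over to the new group.

With nothing readable to build on, no step beyond the scatter is expected in this assay, and the step expected is a step that the limit leaves unreadable from compound 3 to compound 4 in its estimated size. Compound 4 is estimated at 12000 nM, with an expected range from 4000 nM to 30000 nM, and the reading is expected to be most likely a limit again.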

Compound 4, half-maximal inhibitory concentration: 700 nM
Compound 4: middle estimate off by 17-fold (1.23 log units), on the high side; the measured number lies below the stated range.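

In this assay, for the compounds shown here, compound 4 gives 700 nM, the only number that is not a limit, and sulfamoyl in place of cyano on an aromatic carbon, para to a large group, is an at least 14-fold lower number from compound 3 to compound 4 (1.15 log units; beyond the scatter). Against the two other compounds, the 4-sulfamoylphenyl group gives an at least 14-fold lower number from compound 2 to compound 4 (1.15 log units; beyond the scatter) and an at least 14-fold lower number from compound 1 to compound 4 (1.15 log units; beyond the scatter), so the read-out does respond to a change on this aromatic ring, which the earlier compounds could not show. The steps among compound 1, compound 2 and compound 3 cannot be read, as all three stay at one limit: the limit of > 10000 nM in this assay, at which 3 of the 4 values shown sit.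

The compounds shown leave open whether a methylsulfonyl group or a carboxylic acid in the same place would give a number like that of compound 4, or whether the effect is confined to sulfamoyl. Going by these compounds, the full size of each new step also remains open, as compound 4 is compared only with compounds that carry a limit.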